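Triazole-Linked Triterpenoid Analogues Tested on Liver Cancer Cells

The source may report more compounds than this note shows. Statements on the series, on what has been measured and on what is new or still open speak of the compounds shown alone.

Compound 1 `C=C1C[C@]23C[C@@]1(O)CC[C@H]2c1cc(Br)c(O)c(C)c1[C@@H]3Cn1cc(-c2ccc(OC)cc2)nn1`: in a functional assay on SMMC-7721 cells (Homo sapiens) for cytotoxicity, read by MTT assay, with a stated time of 4 days (on this read-out higher numbers stand for weaker inhibition and lower numbers for stronger inhibition), compound 1 gives > 20000 nM, which is a limit of the assay rather than a number.
Compound 2 `COc1ccc(-c2cn(C[C@H]3c4c(ccc(OS(=O)(=O)c5ccc(C)cc5)c4C)[C@@H]4CC[C@@]5(C)C[C@]43CC5=O)nn2)cc1`: in this assay compound 2 gives > 20000 nM, again a limit of the assay.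
Compound 3 `Cc1ccc(-c2cn(C[C@H]3c4c(ccc(O)c4C)[C@@H]4CC[C@@]5(C)C[C@]43CC5=O)nn2)cc1`: in this assay compound 3 gives > 20000 nM, also a limit of the assay.

Compound 2 therefore stands where every measured compound of this set stands: at the limit of > 20000 nM in this assay, at which 3 of the 3 values shown sit, with no numerical value to rank it against compound 1 or compound 3. Among the measured compounds shown here, no step between two measured compounds can be stated, since all three results are limits.

Compound 4 `Cc1ccc(S(=O)(=O)Oc2ccc3c(c2C)[C@H](Cn2cc(-c4ccc(C(F)(F)F)cc4)nn2)[C@@]24CC(=O)[C@@](C)(CC[C@@H]32)C4)cc1` differs from compound 2 in one place: trifluoromethyl in place of methoxy on an aromatic carbon. With every measured result sitting at the limit, there is no basis to expect a movement beyond the scatter in either direction for this change, and the most likely outcome is that compound 4 is also reported only as a limit. Compound 4 is accordingly estimated at 25000 nM, with a range of 8000 nM to 80000 nM, an expected step from compound 2 of a step that the limit leaves unreadable from compound 2 to compound 4.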

Compound 4, half-maximal inhibitory concentration: > 20000 nM
Compound 4 ended at the assay's limit (the forecaster's own chance of this, stated with the estimate: 75%); the middle value is on the limit's open side.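

Compound 2 and compound 4 both rest on a limit of the assay rather than a number, so no step can be read for trifluoromethyl in place of methoxy: the limit of > 20000 nM in this assay, at which 4 of the 4 values shown sit. The compounds shown leave open which change, if any, would give a numerical result in this assay.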